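Bromo versus cyano on the aniline ring of the series

The compounds below may be only part of what the source reports. "The series", "measured", "known", "first", "only" and "open" are said of these compounds alone.

Measured so far:
compound 1, `NS(=O)(=O)NCCSc1nonc1/C(=N/O)Nc1ccc(F)c(Br)c1`, 2.8 nM
compound 2, `CSc1nonc1/C(=N/O)Nc1ccc(F)c(Br)c1`, 15 nM
compound 3, `N#Cc1cc(N/C(=N\O)c2nonc2SCCNC(=O)CS(N)(=O)=O)ccc1F`, 39 nM

All three were read in an assay for inhibition of Indoleamine 2,3-dioxygenase 1 (Homo sapiens), read by fluorescence, with a stated time of 24 h; a lower number here means a stronger inhibitor, a higher number a weaker inhibitor. Compound 3 stands highest of the three numbers: against compound 2 it is beyond the scatter, and against compound 1 it is further still. Within the measured pairs, the only single-point step is a 5.4-fold higher number from compound 1 to compound 2 (0.73 log units; beyond the scatter), which concerns the chain on the sulfur and not the aromatic ring.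

Compound 4, `NS(=O)(=O)CC(=O)NCCSc1nonc1/C(=N/O)Nc1ccc(F)c(Br)c1`, keeps the chain of compound 3 and changes the ring: bromo in place of cyano on an aromatic carbon. Going by the values given here, no measured pair isolates this swap. Compounds 1 and 2 both carry the bromo ring, and compound 3 alone carries the cyano ring, so the comparison between them is mixed with the chain differences. Given that the two bromo-bearing compounds sit lower, a step of a 3.9-fold lower number from compound 3 to compound 4 (0.59 log units; beyond the scatter) toward lower numbers is expected for compound 4 in this assay. Compound 4 is therefore estimated at 10 nM, with a range from 3 nM to 30 nM.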

Compound 4, half-maximal inhibitory concentration: 12 nM
For compound 4 the middle estimate is 1.2-fold (0.08 log units) below the measured one; low and high end bracket the measured number.
By their numbers in this assay, from the lowest: compound 1; then compounds 4 and 2 (each within the scatter of the next); then compound 3.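

With the chain held fixed, a 3.3-fold lower number from compound 3 to compound 4 (0.51 log units; beyond the scatter) isolates the change from 3-cyano-4-fluorophenyl to 3-bromo-4-fluorophenyl in this assay and shows that bromo in place of cyano on this aromatic carbon is a modest gain on its own. Going by these compounds alone, on the bromo ring, the chain matters less simply than the earlier compounds suggested: a 1.3-fold lower number from compound 2 to compound 4 (0.10 log units; within the scatter) does not separate the chain of compound 4 from the hydrogen in its place, while a 4.3-fold higher number from compound 1 to compound 4 (0.63 log units; beyond the scatter) shows that (sulfamoylmethyl)carbonyl on the amine nitrogen gives up most of what sulfamoyl there provides. No evidence on the origin of these steps is at hand.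

From the compounds shown here alone, whether the step from cyano to bromo keeps its size on the chain of compound 1 or compound 2 remains open, as the cyano ring appears here with one chain only. Also open, going by these compounds, is how chloro on the same aromatic carbon, or a carboxylic acid or an amine at the end of the chain, would read.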